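The source may report more compounds than this note shows. Statements on the series, on what has been measured and on what is new or still open speak of the compounds shown alone.

Measured so far in an assay for inhibition of Fatty-acid amide hydrolase 1 (Rattus norvegicus); a higher number here means a weaker inhibitor, a lower number a stronger inhibitor:
Compound 1 `O=C(CCCCC#Cc1cccc(F)c1)c1ncc(-c2ccccn2)o1` gives 3.2 nM.
Compound 2 `O=C(O)c1cccc(CCCCCCC(=O)c2ncc(-c3ccccn3)o2)c1` gives > 600 nM.
Compound 3 `CS(=O)(=O)c1cccc(CCCCCCC(=O)c2ncc(-c3ccccn3)o2)c1` gives 1.3 nM.

Among the compounds with values here, compound 2 stands apart: in this assay its result is a limit and not a number, > 600 nM, and it is the one value of the three that sits at the limit of > 600 nM in this assay, at which 1 of the 3 values shown sits. Within the data shown here, compound 1 and compound 3 both give low numbers, and no step between them is computed here, so only their two values are noted.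

Among the measured compounds shown here, the one measured step that touches compound 2 is an at least 460-fold lower number from compound 2 to compound 3 (2.66 log units; beyond the scatter). It shows that swapping the carboxy for a group with no net charge on the same ring carbon moves the value from the limit to a low number.

Compound 4 `Nc1ccc(CCCCCCC(=O)c2ncc(-c3ccccn3)o2)cc1` is not yet measured. It differs from compound 2 as 4-aminophenyl in place of 3-carboxyphenyl on a saturated chain carbon, six bonds along the chain from a carbonyl carbon. The entering group, like methylsulfonyl in compound 3, carries no net charge, so a large step away from the limit is expected, in the direction of a lower number: the expected step is an at least 100-fold lower number from compound 2 to compound 4 (2.00 log units; beyond the scatter). Compound 4 is therefore estimated at 6 nM, with a range of 1 nM to 40 nM.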

Compound 4, inhibition constant: 3 nM
Compound 4: the middle estimate sits 2.0-fold (0.30 log units) above what was measured; the measured number falls inside the stated range.
By their numbers in this assay, from the lowest: compound 3; then compounds 4 and 1 (each within the scatter of the next). At a limit, above all of these: compound 2.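

In this assay the change gives an at least 200-fold lower number from compound 2 to compound 4 (2.30 log units; beyond the scatter), so a low number at this end of the chain is not confined to the methylsulfonyl group of compound 3; a second, quite different aryl group lacking the carboxy gives one too. Compound 2 remains the only result that is a limit and not a number: the limit of > 600 nM in this assay, at which 1 of the 4 values shown sits. Unlike the step to compound 3, this change replaces the group and also alters where it sits on the ring, so the two contributions cannot be separated.

From the compounds shown here alone, whether the amine itself matters stays open: a hydroxyl or an unsubstituted phenyl at the chain end would bear on that. Also open, going by these compounds, is how an ester or an amide in place of the carboxy would read, and what a longer chain would do.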